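Swapping nitro for but-1-yn-1-yl on a shared core

This account rests on a few compounds, and the source may have more. Where it says the series, first, only, none or still open, it means among the compounds named here.

Measured so far:
compound 1, `O=c1[nH]c(=O)n([C@H]2C[C@H](O)[C@@H](CO)O2)cc1[N+](=O)[O-]`: 130 nM
compound 2, `Nc1ncnc2c1nnn2[C@@H]1C[C@H](CO)[C@@H](CO)[C@H]1CO`: > 200000 nM
compound 3, `Nc1ncnc2c1ncn2C1OC(/C=N/O)CC1O`: > 200000 nM

Of the compounds shown here, three have been tested in an ADME assay on L1210/0 cells (Mus musculus) for cytotoxicity, with a stated time of 48 h; a higher number here means a weaker inhibitor, a lower number a stronger inhibitor. Among the measured compounds shown here, compound 1 is the only one that gives a number, 130 nM. For compound 2 the result is only a limit, > 200000 nM. For compound 3 the result is likewise only a limit, > 200000 nM. For the measured compounds named here, no two of the measured compounds differ in a single place, so no measured step is available; the one piece of evidence is the limit of > 200000 nM in this assay, at which 2 of the 3 values shown sit, which says nothing about how a change on compound 1 would play out.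

Compound 4, `CCC#Cc1cn([C@H]2C[C@H](O)[C@@H](CO)O2)c(=O)[nH]c1=O`, has not yet been tested. It keeps the core of compound 1 and differs in one place: but-1-yn-1-yl in place of nitro on an aromatic carbon. The group that leaves carries two hydrogen-bond acceptors, the group that enters carries none, and the change sits on an aromatic carbon of the core.

Going by the values given here, with no measured step to lean on, the expectation is a move toward weaker inhibition in this assay, of a size well beyond the scatter, a 23-fold higher number from compound 1 to compound 4 (1.36 log units; beyond the scatter). Compound 4 is therefore estimated at 3000 nM, with a plausible range from 300 nM to 30000 nM.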

Compound 4, half-maximal inhibitory concentration: > 200000 nM
Compound 4: a limit, no number; the forecaster's own chance of this, stated with the estimate: 10%; middle value at least 66-fold (1.82 log units) from the limit.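

In this assay, among the compounds shown here, but-1-yn-1-yl in place of nitro on this aromatic carbon gives an at least 1500-fold higher number from compound 1 to compound 4 (3.18 log units; beyond the scatter), the first measured step on the core of compound 1 and a large one. This shows that the position is not indifferent to what it carries: with the rest of the molecule unchanged, this one exchange separates a compound with a measurable number from one without. Compound 4 gives > 200000 nM, which is a limit of the assay and not a number, so the step shows a minimum size and the full size stays unknown, and compound 4 joins the values that sit at this same limit: the limit of > 200000 nM in this assay, at which 3 of the 4 values shown sit.

What remains open is whether the loss comes from taking nitro away or from bringing but-1-yn-1-yl in, since only these two groups at this position are shown and a single pair cannot separate the two. A smaller group such as a nitrile or an amine on the same carbon, or a shorter chain such as ethynyl, would show how much of the step belongs to each side.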